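The source may hold more compounds than are shown below. What is called first, only, known or untested is meant among the compounds shown, and "the series" means these compounds.

Measured compounds in a functional assay on SK-BR-3 cells (Homo sapiens) for antiproliferative activity, read by MTT assay, with a stated time of 72 h; on this read-out higher numbers stand for weaker inhibition and lower numbers for stronger inhibition:

compound 1 `CCNc1cc(C)c2cc(NC(=O)c3ccc(Cl)c(Cl)c3)ccc2n1` gives 28200 nM
compound 2 `CCN1CCN(c2cc(C)c3cc(NC(=O)c4ccccc4C)ccc3n2)CC1` gives 29200 nM
compound 3 `CCN(CC)c1cc(C)c2cc(NC(=O)c3ccc(Cl)c(Cl)c3)ccc2n1` gives 41200 nM

For the measured compounds named here, all three numbers lie within the scatter of one another, so compound 2 is not separated from compound 1 or compound 3 on this read-out; the one single-point step among the measured compounds is a 1.5-fold higher number from compound 1 to compound 3 (0.16 log units; within the scatter), and it concerns the amine on the aromatic ring, not the group on the carbonyl carbon.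

Compound 4 `CCN1CCN(c2cc(C)c3cc(NC(=O)c4ccc(OC)cc4)ccc3n2)CC1` differs from compound 2 in one place: 4-methoxyphenyl in place of 2-methylphenyl on a carbonyl carbon. Going by the values given here, no measured step changes the group on the carbonyl carbon alone; compound 1 and compound 3 carry a different group there, but each also differs from compound 2 at the amine, so their numbers only show that the series as a whole sits in one narrow band.

With nothing in the measured steps pointing either way, the expected step of a 1.0-fold higher number from compound 2 to compound 4 (0.01 log units; within the scatter) is none beyond the scatter. Compound 4 is therefore estimated at 30000 nM, with a range from 10000 nM to 90000 nM.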

Compound 4, half-maximal inhibitory concentration: 9000 nM
Compound 4: the middle estimate sits 3.3-fold (0.52 log units) above what was measured, outside the stated range (below it).
By their numbers in this assay, from the lowest: compound 4; then compounds 1, 2 and 3 (each within the scatter of the next).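

In this assay, for the compounds shown here, 4-methoxyphenyl in place of 2-methylphenyl on a carbonyl carbon gives a 3.2-fold lower number from compound 2 to compound 4 (0.51 log units; beyond the scatter) and is the first single-place step to pass the scatter. The only earlier single-place step, at the amine on the aromatic ring, stayed within the scatter, so the group on the carbonyl carbon is the first position shown to move this read-out. No evidence at hand bears on what lies behind this step.

Since 2-methylphenyl and 4-methoxyphenyl differ both in the group carried and in its numbered place on the phenyl, this single step does not separate the two. Also open, as far as these compounds go, are whether a longer chain such as ethoxy in place of methoxy moves the number further, and whether the step repeats with the amine of compound 1 or compound 3.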